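The source may report more compounds than this note shows. Statements on the series, on what has been measured and on what is new or still open speak of the compounds shown alone.

Series notes. Compound 1 `CNC(=O)Nc1c(C)c(C(OC(C)(C)C)C(=O)O)c(-c2ccc(C)c(C)c2)c(C)c1-c1ccc(C)c(C)c1` and compound 2 `CC(=O)Nc1c(C)c(C(OC(C)(C)C)C(=O)O)c(-c2ccc(C)c(C)c2)c(C)c1-c1ccc(C)c(C)c1` share one core and differ in a single group on a carbonyl carbon. In an ADME assay on MT4 cells (Homo sapiens) for cytotoxicity, read by MTT assay, with a stated time of 4 days (on this read-out higher numbers stand for lower toxicity in this test and lower numbers for higher toxicity in this test), compound 1 gives 20000 nM, and compound 2 gives 19000 nM. The only measured step, a 1.1-fold lower number from compound 1 to compound 2 (0.02 log units; within the scatter), lies within the scatter, so compound 2 stands level with compound 1 on the two numbers shown, and neither can be ranked against the other. Compound 3 `Cc1ccc(-c2c(C)c(-c3ccc(C)c(C)c3)c(C(OC(C)(C)C)C(=O)O)c(C)c2NS(=O)(=O)c2ccccc2)cc1C` is the next change: phenylsulfonyl in place of acetyl on a nitrogen on an aromatic ring. Among the compounds with values here, no measured step bears on a change of this kind; the one step on hand, a 1.1-fold lower number from compound 1 to compound 2 (0.02 log units; within the scatter), concerns a different exchange and was within the scatter. The two numbers shown give no lean in either direction, so no step beyond the scatter is expected in this assay. The step expected from this change is a 1.3-fold lower number from compound 2 to compound 3 (0.10 log units; within the scatter). Compound 3 is estimated at 15000 nM, with a range from 6000 nM to 40000 nM.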

Compound 3, half-maximal cytotoxic concentration: 11000 nM
Beside the measured number, compound 3's estimate is 1.4-fold (0.13 log units) above it; low and high end bracket the measured number.
By their numbers in this assay, from the lowest: compounds 3, 2 and 1 (each within the scatter of the next).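

On the nitrogen on an aromatic ring, the exchange now reaches a group carrying a six-membered aromatic ring of its own: with phenylsulfonyl in place of acetyl, this assay shows a 1.7-fold lower number from compound 2 to compound 3 (0.24 log units; within the scatter) and stays within the scatter. With phenylsulfonyl in place of methylcarbamoyl, the same place gives a 1.8-fold lower number from compound 1 to compound 3 (0.26 log units; within the scatter) and also stays within the scatter, so the three groups shown at this position cannot be ranked, even with an aromatic ring added. Nothing further is at hand to explain these numbers.

As far as these compounds go, whether an amine or a carboxylic acid at this nitrogen would give a step beyond the scatter remains open. A longer chain in place of acetyl, or a chlorine on the phenyl ring of the phenylsulfonyl group, is equally untested in the compounds shown here.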